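Swapping a selenium chain for a small selenium group

The source may hold more compounds than are shown below. What is called first, only, known or untested is meant among the compounds shown, and "the series" means these compounds.

Compound 1 (`COc1ccc(N(C)c2nc(C)nc3ccccc23)cc1OCCC[Se]C#N`) gives 815 nM in a functional assay on MDA-MB-231 cells (Homo sapiens) for inhibition, read by MTT assay, with a stated time of 48 h; a lower number here means a stronger inhibitor, a higher number a weaker inhibitor
Compound 2 (`COc1ccc(N(C)c2nc(C)nc3ccccc23)cc1C(=O)OCC[Se]C#N`) gives 1480 nM in this assay

Only these two numbers exist so far, and they cannot be told apart. The step between them, a 1.8-fold higher number from compound 1 to compound 2 (0.26 log units; within the scatter), stays within the scatter, so compound 1 stands level with compound 2.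

Compound 3 (`COc1ccc(N(C)c2nc(C)nc3ccccc23)cc1[Se]C`) has not been measured yet. Its difference from compound 1 is a group of 2 heavy atoms (1 carbon, 1 selenium; no ring) in place of a group of 7 heavy atoms (4 carbon, 1 nitrogen, 1 oxygen, 1 selenium; no ring), on an aromatic carbon and the shared core stays the same. The group that leaves holds a triple bond outside aromatic rings, and the group that enters has none.

Compound 2 gives only weak guidance here. Its step, a 1.8-fold higher number from compound 1 to compound 2 (0.26 log units; within the scatter), exchanged one long group for another of much the same size, whereas compound 3 loses most of that group. A change beyond the scatter therefore seems likely, although the data do not settle its direction. The expected shift, leaning towards a stronger inhibitor, is a 3.3-fold lower number from compound 1 to compound 3 (0.51 log units; beyond the scatter) as a tentative estimate. For compound 3 the estimated value in this assay is 250 nM with an expected range of 30 nM to 1500 nM at this stage.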

Compound 3, half-maximal inhibitory concentration: 10 nM
For compound 3 the middle estimate is 25-fold (1.40 log units) above the measured one; the measured number lies below the stated range.
By their numbers in this assay, from the lowest: compound 3; then compounds 1 and 2 (each within the scatter of the next).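

At this aromatic carbon, ortho to a methoxy group, this assay shows an 82-fold lower number from compound 1 to compound 3 (1.91 log units; beyond the scatter) when the group of 7 heavy atoms gives way to the group of 2 heavy atoms, and a 150-fold lower number from compound 2 to compound 3 (2.17 log units; beyond the scatter) when the group of 8 heavy atoms gives way to the same small group. The two longer groups had left no readable difference, so only compound 3 shows that this position can strongly change the result, and its steps to both others make compound 3 the strongest inhibitor of the three. No measurement shown here explains the size of these steps.

The change to compound 3 shortens the chain and removes the nitrile with its triple bond in a single step, so the compounds shown cannot say which of these matters, or whether both do. From the compounds shown here alone, it also remains open how this result would compare with an ethyl group on the selenium, a longer carbon chain on the selenium without a nitrile, or a methylthio group, with sulfur in place of selenium.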